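The source may hold more compounds than are shown below. What is called first, only, known or untested is meant among the compounds shown, and "the series" means these compounds.

Measured compounds:
Compound 1 `c1ccc2c(c1)CN[C@@H](CN(CCCCNCC1CCOCC1)[C@H]1CCCc3cccnc31)C2` — in a functional assay on cells for agonist activity at C-X-C chemokine receptor type 4 (Homo sapiens), read by fluorescence and calcium flux, with a stated time of 90 s (a higher number here means that more compound is needed for the effect, a lower number that less compound is needed), compound 1 gives > 30000 nM, which is a limit of the assay and not a number.
Compound 2 `c1ccc2c(c1)CN[C@@H](CN(CCCCNCC1CCNCC1)[C@H]1CCCc3cccnc31)C2` — in this assay compound 2 gives > 30000 nM, again a limit.
Compound 3 `c1ccc2c(c1)CN[C@@H](CN(CCCCNC1CCCCC1)[C@H]1CCCc3cccnc31)C2` — in this assay compound 3 gives > 30000 nM, again a limit.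

Within the data shown here, compound 2 stands where the other two stand: every value so far sits at the same limit (the limit of > 30000 nM in this assay, at which 3 of the 3 values shown sit), so no order among the three can be read. The step piperidin-4-yl in place of oxan-4-yl on a saturated chain carbon bound to an amine nitrogen is a step that the two limits leave unreadable from compound 1 to compound 2. Cyclohexyl in place of (oxan-4-yl)methyl on an amine nitrogen gives a step that the two limits leave unreadable from compound 1 to compound 3, and cyclohexyl in place of (piperidin-4-yl)methyl on an amine nitrogen gives a step that the two limits leave unreadable from compound 2 to compound 3.

Compound 4 `CC(C)(CN)CCN(C[C@H]1Cc2ccccc2CN1)[C@H]1CCCc2cccnc21` is not yet measured. Relative to compound 2 the change is a group of 5 heavy atoms (4 carbon, 1 nitrogen; no ring) in place of a group of 10 heavy atoms (8 carbon, 2 nitrogen; one six-membered non-aromatic ring with 1 hetero atom), on a saturated chain carbon, two bonds along the chain from an amine nitrogen. Among the measured compounds shown here, none of the measured steps covers this change, and all three start and end at the limit, carrying no readable size. There is thus no basis for a directed expectation in this assay beyond the limit itself. The expected step is a step that the limit leaves unreadable from compound 2 to compound 4. Compound 4 is expected to give about 40000 nM, within 8000 nM to 200000 nM, with a high chance that the assay again reports only a limit.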

Compound 4, half-maximal effective concentration: > 30000 nM
Compound 4: no number, only a limit (the forecaster's own chance of this, stated with the estimate: 80%); the middle value does not contradict the limit.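

In this assay compound 4 gives > 30000 nM, which is a limit and not a number. No step from compound 1, compound 2 or compound 3 to compound 4 can be read, and the series stays at a single limit: the limit of > 30000 nM in this assay, at which 4 of the 4 values shown sit.

The compounds shown leave open whether any chain on the shared core gives a readable value in this assay, and how these groups would rank.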